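The compounds below may be only part of what the source reports. "The series", "measured", "known", "first", "only" and "open" are said of these compounds alone.

Working notes on the series.

Compound 1, with structure `COc1cccc(-c2cc(C)cn3c(CSCCc4ccccc4)cnc23)c1`, is the reference point. In an ADME assay on HEL cells (Homo sapiens) for cytotoxicity, with a stated time of 3 days (on this read-out lower numbers stand for higher toxicity in this test and higher numbers for lower toxicity in this test), compound 1 gives > 50 ug/mL, which is a limit of the assay and not a number, so its position is known only as the limit of > 50 ug/mL in this assay, at which 1 of the 3 values shown sits. The two other measured members give numbers in this assay. Compound 2, with structure `COc1ccc(-c2cc(C)c3ncc(CSCCc4ccccc4)n3c2)cc1`, gives 25.8 ug/mL in this assay. Compound 3, with structure `c1ccc(CCSCc2cnc3ccc(-c4ccccc4)cn23)cc1`, gives 9.9 ug/mL in this assay. Among the measured compounds shown here, no single-point step between any two measured compounds is recorded, so no measured effect of any one change is available.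

The unmeasured compound 4, with structure `Cc1cc(-c2cccc([N+](=O)[O-])c2)c2ncc(CSCCc3ccccc3)n2c1`, differs from compound 1 by one change: nitro in place of methoxy on an aromatic carbon. That is, nitro in place of methoxy on an aromatic carbon of a six-membered aromatic ring of carbon only, meta to a large group; read one bond further out, 3-methoxyphenyl becomes 3-nitrophenyl.

Nothing in the recorded values shows what this exchange does in this assay. Compound 4 is therefore expected to remain close to compound 1, with a step of an at least 1.2-fold lower number from compound 1 to compound 4 (0.09 log units; that floor lies within the scatter) expected, not clearly beyond the scatter in either direction. For compound 4 the estimate in this assay is 40 ug/mL, within a range from 15 ug/mL to 80 ug/mL, with a fair chance that only a limit is again reported.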

Compound 4, half-maximal cytotoxic concentration: 47 ug/mL
Beside the measured number, compound 4's estimate is 1.2-fold (0.07 log units) below it; measured number inside the range.
By their numbers in this assay, from the lowest: compound 3; then compounds 2 and 4 (each within the scatter of the next). At a limit, above all of these: compound 1.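

The exchange of methoxy for nitro on this aromatic carbon now has a first read in this assay, which gives an at least 1.0-fold lower number from compound 1 to compound 4 (0.02 log units; that floor lies within the scatter). Going by these compounds, that figure is only a floor, and the true size of the step stays unknown because compound 1 stands at a limit and not at a number: the limit of > 50 ug/mL in this assay, at which 1 of the 4 values shown sits. What the earlier compounds could not show is that this place, on a six-membered aromatic ring of carbon only and meta to a large group, can carry nitro as well as methoxy with no step shown beyond the scatter, although a larger true step is not excluded.

The compounds shown leave open whether an amine or a carboxylic acid on this same aromatic carbon would give a step clearly beyond the scatter in this assay. Among the compounds shown here, they also hold no pair in which the 3-methoxyphenyl to 3-nitrophenyl exchange runs between two numbers, so neither its real size nor its direction is settled.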